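Isomeric hydroxyalkyl chains and growth inhibition in the series

The compounds below may be only part of what the source reports. "The series", "measured", "known", "first", "only" and "open" are said of these compounds alone.

compound 1 `CCC(O)[C@@H](CC)Nc1nc(NCc2ccccn2)c2ncn(C(C)C)c2n1` gives 26000 nM
compound 2 `CC[C@@H](Nc1nc(NCc2ccccn2)c2ncn(C(C)C)c2n1)C(O)C(C)(C)C` gives 27000 nM
compound 3 `CC[C@H](Nc1nc(NCc2ccccn2)c2ncn(C(C)C)c2n1)C(C)(C)O` gives 26000 nM

In a functional assay on CH1 cells (Homo sapiens) for inhibition, read by sulforhodamine B assay, with a stated time of 96 h (a lower number here means a stronger inhibitor of growth, a higher number a weaker inhibitor of growth), compound 3 stands level with compound 1 , and compound 2 lies within the scatter of both. The next structure is compound 4 `CCC(O)[C@H](CC)Nc1nc(NCc2ccccn2)c2ncn(C(C)C)c2n1`, which has 1-hydroxypropyl in place of 1-hydroxy-1-methylethyl on a saturated chain carbon bound to a nitrogen on an aromatic ring and a saturated chain carbon.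

The closest measured evidence is the exchange between the same two side chains, read in the opposite direction: no change at the digits printed from compound 1 to compound 3 (within the scatter). The tert-butyl for ethyl exchange gives a 1.0-fold higher number from compound 1 to compound 2 (0.02 log units; within the scatter), and the remaining pair gives a 1.0-fold lower number from compound 2 to compound 3 (0.02 log units; within the scatter). All three steps lie within the scatter, so these three compounds show no response to the chain changes made so far. For the measured compounds named here, no measured pair changes only the handedness at the carbon bound to nitrogen, so that question stays open and the range is kept wide.

No step beyond the scatter is expected, and the estimated step is a 1.0-fold lower number from compound 3 to compound 4 (0.02 log units; within the scatter). The estimate for compound 4 is 25000 nM, with an expected range from 11000 nM to 45000 nM.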

Compound 4, concentration for 50% growth inhibition: 26000 nM
For compound 4 the middle estimate is 1.0-fold (0.02 log units) below the measured one; low and high end bracket the measured number.
By their numbers in this assay, from the lowest: compounds 1, 3, 4 and 2 (each within the scatter of the next).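

In this assay, for the compounds shown here, the handedness at the saturated chain carbon bound to a nitrogen on an aromatic ring now has a direct reading, which the earlier compounds did not give: no change at the digits printed from compound 1 to compound 4 (within the scatter). The new compound also extends the insensitivity to chain shape, with 1-hydroxypropyl in place of 1-hydroxy-1-methylethyl giving no change at the digits printed from compound 3 to compound 4 (within the scatter), and 1-ethyl-2-hydroxybutyl in place of 1-ethyl-2-hydroxy-3,3-dimethylbutyl giving a 1.0-fold lower number from compound 2 to compound 4 (0.02 log units; within the scatter). The reading of handedness carries one limit, since it rests on a single pair whose drawings are not fully matched: the fact that one of compounds 1 and 4 is drawn with a defined configuration and the other without, at the place where they differ.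

All four compounds carry a hydroxyl-bearing chain and sit within the scatter of one another, so the compounds shown do not reveal whether any change on this chain can move the number beyond the scatter. Still open, from the compounds shown here alone, are the effect of an amine or a carboxylic acid in place of the hydroxyl, the effect of a longer chain, and the role of the hydroxyl-bearing carbon, which has no drawn configuration in compounds 1, 2 and 4.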